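Toward a Lower Number at Compound 3

The source may hold more compounds than are shown below. What is called first, only, known or untested is meant among the compounds shown, and "the series" means these compounds.

Measured in an ADME assay on WI-38 cells (Homo sapiens) for cytotoxicity, read by MTT assay, with a stated time of 72 h; a higher number here means a weaker inhibitor, a lower number a stronger inhibitor:
- compound 1 `CSc1cccc(-c2cccc(NC(=O)CCc3cccc4c3B(O)OC4)c2)c1`: 2000 nM
- compound 2 `O=C(CCc1cccc2c1B(O)OC2)Nc1cccc(-c2ccc(C(F)(F)F)cc2)c1`: 26000 nM

Among the measured compounds shown here, compound 2, at 26000 nM, holds the higher of the two numbers in this assay, and compound 1 is its only neighbour. The next change leads to compound 3 `N#Cc1cccc(-c2cccc(NC(=O)CCc3cccc4c3B(O)OC4)c2)c1`: 3-cyanophenyl in place of 4-(trifluoromethyl)phenyl on an aromatic carbon, meta to a large group (3-cyanophenyl in place of 4-(trifluoromethyl)phenyl on an aromatic carbon). For the measured compounds named here, one measured step bears on it: a 13-fold higher number from compound 1 to compound 2 (1.11 log units; beyond the scatter), a large change beyond the scatter, with 4-(trifluoromethyl)phenyl in place of 3-(methylsulfanyl)phenyl. Compound 3 carries its group at the same numbered position as the 3-(methylsulfanyl)phenyl of compound 1, which gives 2000 nM, so a return toward that value is expected. With one step as evidence, this expectation is loose. The expected change, toward a lower number, is a 4.3-fold lower number from compound 2 to compound 3 (0.64 log units; beyond the scatter). Compound 3 is estimated at 6000 nM, with an expected range of 1800 nM to 20000 nM.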

Compound 3, half-maximal inhibitory concentration: 7300 nM
Estimate against measurement, compound 3: 1.2-fold (0.09 log units) below; the measured number falls inside the stated range.
By their numbers in this assay, from the lowest: compound 1; then compound 3; then compound 2.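

In this assay the change to 3-cyanophenyl in place of 4-(trifluoromethyl)phenyl gives a 3.6-fold lower number from compound 2 to compound 3 (0.55 log units; beyond the scatter) and shows that the number at this position can also fall, not only rise. Cyano in place of methylsulfanyl, with the group at the same numbered position, still gives a 3.7-fold higher number from compound 1 to compound 3 (0.56 log units; beyond the scatter) and shows that the number depends on the group itself and not on its numbered position alone. Nothing available accounts for either step.

As far as these compounds go, compound 2 differs from compound 3 in both the group and its numbered position, so the share of each in that step remains open. Also open, from the compounds shown here alone, is where an amine or a carboxylic acid in place of the cyano group would fall relative to compound 1 and compound 3.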